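Cytotoxicity notes on the benzyl variants, compounds 2 and 3

This account rests on a few compounds, and the source may have more. Where it says the series, first, only, none or still open, it means among the compounds named here.

Two compounds of the series have been taken into a toxicity assay on NIH3T3 cells (Mus musculus) for cytotoxicity, read by resazurin assay; a higher number here means that more compound is needed for the effect, a lower number that less compound is needed. In this readout, compound 1 (`COC(=O)c1ccc(NCc2cncn2Cc2ccccc2C)cc1-c1ccccc1`) gives 10000 nM. Compound 2 (`COC(=O)c1ccc(NCc2cncn2Cc2cccc(OC)c2)cc1-c1ccccc1`) has no usable result, with its entry reading "not determined" (no result reported), so compound 2 has no position on the scale and cannot serve as a numerical starting point. Compound 3 (`COC(=O)c1ccc(NCc2cncn2Cc2ccc(Br)cc2)cc1-c1ccccc1`) has not yet been measured.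

The structural step is 4-bromophenyl in place of 3-methoxyphenyl on a saturated chain carbon bound to an aromatic nitrogen, which puts 4-bromophenyl in place of 3-methoxyphenyl on a saturated chain carbon bound to an aromatic nitrogen. The shared core stays unchanged. Within the data shown here, the series offers no measured step between two compounds, so the effect of this exchange in this assay cannot be sized from the data. Among the measured compounds shown here, no shift beyond the usual scatter is expected, in either direction, and the only anchor is compound 1 at 10000 nM. This is a weak basis resting on a single number, so the range is kept wide.

For compound 3 the expected value is 10000 nM, with an estimated range of 3000 nM to 30000 nM.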

Compound 3, half-maximal effective concentration: > 10000 nM
Compound 3 was reported as a limit; the forecaster's own chance of this, stated with the estimate: 35%; the middle value lies on the limit itself.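

Compound 3 gives > 10000 nM in this assay, which is a limit of the assay and not a number. Among these compounds, on a saturated chain carbon bound to an aromatic nitrogen, 4-bromophenyl in place of 2-methylphenyl gives a number no lower from compound 1 to compound 3 (the limit leaves the size open), the first comparison at this position that can be read at all, and it shows that this exchange does not lower the concentration needed for the effect. How large the step is cannot be read, so the result gives a direction only, and the reading at this position is bounded by the assay: the limit of > 10000 nM in this assay, at which 1 of the 3 values shown sits.

The compounds shown leave open whether any group at this position brings the number clearly down from that limit, for example a benzyl carrying an amine or a carboxylic acid, or a longer chain in place of the benzyl. They also leave open whether 4-chlorophenyl or 4-fluorophenyl would read as 4-bromophenyl does in this assay.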